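A few compounds are considered here, and "the series" means these few. Any claim that something is new, unique, unknown or untested is made for them only; others in the source may bear on it.

Compound 1 `CCOC(=O)c1c(-c2cccc(-c3ccccc3)c2)[nH]c2cc(OC)ccc2c1=O`: > 21500 nM (a limit)
Compound 2 `CCOC(=O)c1c(-c2cccc(OCc3ccccc3)c2)[nH]c2cc(OC)ccc2c1=O`: > 21500 nM (a limit)

In an ADME assay on BJ cells (Homo sapiens) for cytotoxicity, read by luminescence, with a stated time of 72 h (a higher number here means that more compound is needed for the effect, a lower number that less compound is needed), compound 2 gives > 21500 nM as a limit of the assay, not a number. Compound 2 therefore stands, together with compound 1, at the limit of > 21500 nM in this assay, at which 2 of the 2 values shown sit, in the data so far. For the measured compounds named here, the one measured step, a step that the two limits leave unreadable from compound 1 to compound 2, offers no size to carry forward.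

Compound 3 `CCOC(=O)c1c(-c2cccc(OC(F)(F)F)c2)[nH]c2cc(OC)ccc2c1=O` has trifluoromethyl in place of benzyl on an oxygen on an aromatic ring. The expectation for compound 3 rests only on compound 1 and compound 2 sharing the limit of > 21500 nM in this assay, at which 2 of the 2 values shown sit, as their result, so no shift in either direction is expected in this assay. The expected outcome is a step that the limit leaves unreadable from compound 2 to compound 3, with nothing beyond the scatter. Compound 3 is estimated at 25000 nM, with an expected range of 14000 nM to 45000 nM, and will most likely be reported as a limit again.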

Compound 3, half-maximal effective concentration: > 21500 nM
Compound 3: no number, only a limit; the forecaster's own chance of this, stated with the estimate: 85%; the middle value does not contradict the limit.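

In this assay, for the compounds shown here, compound 3 gives > 21500 nM, a limit and not a number, so no step among compound 1, compound 2 and compound 3 can be read. The compounds shown leave open how far each lies from that limit, and whether any group in this place gives a readable value.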